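A few compounds are considered here, and "the series" means these few. Any claim that something is new, unique, unknown or untested is made for them only; others in the source may bear on it.

Measured compounds:
compound 1 `CC(CO)NC(=O)/C=C/c1ccccc1` — 96%
compound 2 `CCC(O)CNC(=O)/C=C/c1ccccc1` — 92%

In a toxicity assay on HepG2 cells (Homo sapiens) for cytotoxicity, read by trypan blue exclusion, with a stated time of 24 h, tested at 50 uM (on this read-out higher numbers stand for a weaker effect at the one concentration tested and lower numbers for a stronger effect), compound 1 gives 96%, the higher of the two numbers recorded, and compound 2 gives 92%. Going by the values given here, the one measured step is a number 4 percentage points lower from compound 1 to compound 2 (within the scatter), so the two compounds cannot be ordered against each other.

Compound 3 `CC(C)C(CO)NC(=O)/C=C/c1ccccc1` differs from compound 1 by isopropyl in place of methyl on a saturated chain carbon bound to an amide-type nitrogen and a saturated chain carbon. Among the compounds with values here, the only step that bears on it is the one between the two measured compounds: it also reshapes the group on the amide-type nitrogen, and it stayed within the scatter. That step gives no sign that a change of this kind moves the read-out, so the account expects no step beyond the scatter in this assay, namely a number 3 percentage points lower from compound 1 to compound 3 (within the scatter). Compound 3 is therefore estimated at 93%, with a range from 80% to 100%.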

Compound 3, a percentage reported as activity, at one concentration (the size of the read-out at that concentration, not a potency): 93%
Beside the measured number, compound 3's estimate shows no gap at the digits printed; the range from low to high includes it.
By their numbers in this assay, from the lowest: compounds 2, 3 and 1 (each within the scatter of the next).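

In this assay, isopropyl in place of methyl on a saturated chain carbon bound to an amide-type nitrogen and a saturated chain carbon gives a number 3 percentage points lower from compound 1 to compound 3 (within the scatter). Where the earlier step reshaped the group on the amide-type nitrogen, this one shows that a group of 3 heavy atoms can replace one of 1 heavy atom at this place without the read-out separating the two compounds. Nothing available gives a reason for this result.

Only methyl and isopropyl are shown at this place, so it stays open whether a longer chain, an amine or a carboxylic acid there would also stay within the scatter. Equally open, as far as these compounds go, is what a fluorine or a methoxy group elsewhere on the core of compound 1 would do to the read-out.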